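The compounds below may be only part of what the source reports. "The series", "measured", "known", "first", "only" and "open" are said of these compounds alone.

Compound 1 `Cc1ccc(S(=O)(=O)NN2C(=S)S/C(=C\c3ccc(Cl)c(Cl)c3)C2O)cc1`: > 100000 nM
Compound 2 `N#Cc1ccc(/C=C2\SC(=S)N(NS(=O)(=O)c3ccccc3)C2=O)cc1`: > 100000 nM

Both entries come from a functional assay on HFF cells (Homo sapiens) for cytotoxicity (on this read-out higher numbers stand for weaker inhibition and lower numbers for stronger inhibition), and neither is a number. Compound 1 stands at the limit of > 100000 nM in this assay, at which 2 of the 2 values shown sit, so only a limit is known for it. Compound 3 `O=S(=O)(NN1C(=S)S/C(=C\c2ccc(Cl)c(Cl)c2)C1O)c1ccccc1F` differs from compound 1 in one place: 2-fluorophenyl in place of 4-methylphenyl on a sulfonyl sulfur. This puts 2-fluorophenyl in place of 4-methylphenyl on a sulfonyl sulfur, and the rest of the structure stays the same. Within the data shown here, no measured step shows what such an exchange does. With compound 1 at its limit of > 100000 nM, no step beyond the usual scatter is expected in this assay, in either direction. The estimated change is a number no higher from compound 1 to compound 3 (the limit leaves the size open). For compound 3 the expected value is 100000 nM, with an estimated range of 40000 nM to 200000 nM.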

Compound 3, half-maximal inhibitory concentration: > 100000 nM
Compound 3 was reported as a limit (the forecaster's own chance of this, stated with the estimate: 85%); the middle value lies on the limit itself.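

In this assay compound 1 and compound 3 are both reported only as limits, so no step can be read between them: the limit of > 100000 nM in this assay, at which 3 of the 3 values shown sit. The compounds shown leave open whether 2-fluorophenyl and 4-methylphenyl on the sulfonyl sulfur differ at all on this read-out.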